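The compounds below may be only part of what the source reports. "The series", "measured", "known", "first", "only" and "open" are said of these compounds alone.

Measured so far:
- compound 1, `O=C(/C=C/c1ccc(Cl)cc1)N1CCC=CS1(=O)=O`: 26400 nM
- compound 2, `O=C(/C=C/c1c[nH]c2ccc(F)cc12)N1CCC=CS1(=O)=O`: 18800 nM
- compound 3, `O=C(/C=C/c1ccccc1F)N1CCC=CS1(=O)=O`: 13700 nM

All three were tested in a functional assay on HeLa cells (Homo sapiens) for inhibition, read by sulforhodamine B assay, with a stated time of 48 h; a higher number here means a weaker inhibitor of growth, a lower number a stronger inhibitor of growth. Compound 1 gives the highest of the three numbers, but its gaps to compound 2 and to compound 3 both lie within the usual scatter, so the three cannot be told apart on these data. All three share the same core and differ only in the aromatic part attached to the double bond.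

Compound 4, `Cc1ccc(/C=C/C(=O)N2CCC=CS2(=O)=O)cc1`, has not been measured. It differs from compound 1 in one place: methyl in place of chloro on an aromatic carbon. Within the data shown here, no measured pair shows what such a swap does here. Given the narrow band of the three numbers, no step beyond the scatter is expected, and compound 4 is estimated at 25000 nM (range 10000 nM to 60000 nM), which would mean a 1.1-fold lower number from compound 1 to compound 4 (0.02 log units; within the scatter).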

Compound 4, concentration for 50% growth inhibition: 18600 nM
The estimate for compound 4 lay 1.3-fold (0.13 log units) above the measured number; the range from low to high includes it.
By their numbers in this assay, from the lowest: compounds 3, 4, 2 and 1 (each within the scatter of the next).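

Among these compounds, this is the first direct comparison at a single position: on the six-membered aromatic ring, para to a large group, methyl in place of chloro gives a 1.4-fold lower number from compound 1 to compound 4 (0.15 log units; within the scatter) in this assay. At this position, then, these two groups cannot be told apart by this read-out. No independent measurement bears on the reason for this result. Still open, as far as these compounds go, is whether an amine, a carboxylic acid or a longer chain at the same position would give a step beyond the scatter. From the compounds shown here alone, whether any change to the shared core would do so also remains open.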